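The source may hold more compounds than are shown below. What is called first, only, known or untested is meant among the compounds shown, and "the series" means these compounds.

Series in a functional assay on cells (Platelet, Homo sapiens) for inhibition; a lower number here means a stronger inhibitor, a higher number a weaker inhibitor:
- compound 1 `CCOC(=O)c1ccc(-c2nn(Cc3cccc(OC)c3)c3ccccc23)cc1`: > 10000 nM
- compound 2 `CCCn1nc(-c2ccc(C(=O)OCC)cc2)c2ccccc21`: > 10000 nM
- compound 3 `O=C(O)c1ccc(-c2nn(Cc3ccccc3)c3ccccc23)cc1`: > 10000 nM

All three entries are limits of the assay, not numbers: the limit of > 10000 nM in this assay, at which 3 of the 3 values shown sit. In this assay compound 3 stands at > 10000 nM, which is a limit. Its true position cannot be read, and it has no numerical value to serve as a starting point.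

The change to compound 4 `CC(C)OC(=O)c1ccc(-c2nn(Cc3ccccc3)c3ccccc23)cc1` is isopropyl in place of hydrogen on an oxygen next to a carbonyl group, or carboxy to isopropoxycarbonyl.

Within the data shown here, the only measured step is a step that the two limits leave unreadable from compound 1 to compound 2. It has no readable size and lies at a different place in the structure, so it gives no direct measure of this change. The closest comparison is with the two esters. Compound 1 also carries an ester on the carbonyl and sits at > 10000 nM, a limit. Compound 2 carries the same ester and sits at > 10000 nM, also a limit.

With no measured number in the series, the expectation is weak. Most likely compound 4 also stays at the limit, and any readable value would lie toward stronger inhibition. The expected step is an at least 1.2-fold lower number from compound 3 to compound 4 (0.09 log units; that floor lies within the scatter). For compound 4 the estimated value is 8000 nM, with an expected range of 800 nM to 20000 nM.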

Compound 4, half-maximal inhibitory concentration: > 10000 nM
Compound 4 gave a limit, no number; the forecaster's own chance of this, stated with the estimate: 55%; middle value at least 1.2-fold (0.09 log units) away from the limit.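

Compound 4 gives a limit in this assay, as compound 3 does, so the step between them cannot be read. The whole series sits at one limit: the limit of > 10000 nM in this assay, at which 4 of the 4 values shown sit.

The compounds shown leave open how strongly any of them inhibits, and whether isopropoxycarbonyl in place of carboxy changes the read-out at all.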